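The source may report more compounds than this note shows. Statements on the series, on what has been measured and on what is new or still open speak of the compounds shown alone.

Measured so far: compound 1 `COc1cc(Cl)cc(-c2nn(-c3cccc(NC(=O)Nc4ccc(Cl)c(C(F)(F)F)c4)c3)cc2-c2ccncc2)c1` gives 2.76% in a functional assay on NCI-H460 cells (Homo sapiens) for inhibition, read by sulforhodamine B assay, with a stated time of 48 h, tested at 10 uM (on this read-out higher numbers stand for a weaker effect at the one concentration tested and lower numbers for a stronger effect), and compound 2 `COc1cc(Cl)cc(-c2nn(-c3cccc(NC(=O)Nc4ccc(Cl)c(Cl)c4)c3)cc2-c2ccncc2)c1` gives 3.1% in the same assay.

On these two numbers compound 2 stands highest, but only just: its nearest neighbour is compound 1, and the step of a number 0.3 percentage points higher from compound 1 to compound 2 (within the scatter) is within the scatter, so the two are not told apart.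

Compound 3 `COc1cc(Cl)cc(-c2nn(-c3cccc(NC(=O)Nc4cccc(C(F)(F)F)c4)c3)cc2-c2ccncc2)c1` has not yet been measured. It differs from compound 2 in one place: 3-(trifluoromethyl)phenyl in place of 3,4-dichlorophenyl on an amide-type nitrogen. Going by the values given here, the only measured step that bears on this is a number 0.3 percentage points higher from compound 1 to compound 2 (within the scatter), which also exchanges chloro and trifluoromethyl on the same ring and stays within the scatter. That step does not cover the loss of the second chlorine, for which no measurement exists, so the expectation rests on a single, small step. On that basis the step of a number 0.9 percentage points higher from compound 2 to compound 3 (within the scatter) is expected to be small, with no change beyond the scatter in either direction.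

Compound 3 is therefore estimated to give 4% in this assay, within a range from 1% to 15%.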

Compound 3, a percentage reported as activity, at one concentration (the size of the read-out at that concentration, not a potency): -6.11%
Compound 3: the middle estimate sits 10.1 percentage points above what was measured, and the stated range ends above it.
By their numbers in this assay, from the lowest: compounds 3, 1 and 2 (each within the scatter of the next).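

With the chloro of compound 1 gone, the step of a number 8.9 percentage points lower from compound 1 to compound 3 (within the scatter) shows that in this assay this aryl group on the amide-type nitrogen keeps the read-out within the scatter with a lone trifluoromethyl group on its ring, a case the earlier pair, which both carried two substituents there, did not cover. The step of a number 9.2 percentage points lower from compound 2 to compound 3 (within the scatter) adds that 3-(trifluoromethyl)phenyl and 3,4-dichlorophenyl are not told apart here, so all three compounds remain within the scatter of one another and neither the chloro nor the second substituent can be called necessary on this evidence. Nothing shown here bears on why the numbers fall where they do.

On these data alone, the three compounds keep a halogen-bearing phenyl ring at this place, so it remains open whether a carboxylic acid, an amine or a methoxy group on that ring, or an unsubstituted phenyl, would stay within the same narrow range of numbers. As far as these compounds go, with a single concentration behind each number, whether compound 1, compound 2 and compound 3 would differ in the strength of their effect at any other concentration also remains open.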